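Azetidinone series: phenoxy in place of cyclopropyl on the core

A few compounds are considered here, and "the series" means these few. Any claim that something is new, unique, unknown or untested is made for them only; others in the source may bear on it.

Measured compounds:
compound 1 `CCOc1ccc(C2C(C3CC3)C(=O)N2c2cc(OC)c(OC)c(OC)c2)cc1`, 63 nM
compound 2 `CCSc1ccc(C2CC(=O)N2c2cc(OC)c(OC)c(OC)c2)cc1`, 311 nM
compound 3 `COc1cc(N2C(=O)C(C3CC3)C2c2ccc(SC)cc2)cc(OC)c1OC`, 204 nM

In a functional assay on HT-29 cells (Homo sapiens) for inhibition, read by sulforhodamine B assay, with a stated time of 72 h (on this read-out higher numbers stand for weaker inhibition and lower numbers for stronger inhibition), compound 1 gives the lowest of the three numbers; the nearest is compound 3, the furthest compound 2. Among the compounds with values here, the only single-place step recorded is a 3.2-fold higher number from compound 1 to compound 3 (0.51 log units; beyond the scatter), which concerns the aromatic substituent, not the saturated ring carbon. Compound 4 `CCOc1ccc(C2C(Oc3ccccc3)C(=O)N2c2cc(OC)c(OC)c(OC)c2)cc1` differs from compound 1 by phenoxy in place of cyclopropyl on a saturated ring carbon. Within the data shown here, no measured pair bears on this position, so the direction is open; a step of about the size seen between compound 1 and compound 3, toward a higher number, is taken as the working expectation, a 2.4-fold higher number from compound 1 to compound 4 (0.38 log units; beyond the scatter). Compound 4 is therefore estimated at 150 nM, within 40 nM to 600 nM.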

Compound 4, half-maximal inhibitory concentration: 388 nM
For compound 4 the middle estimate is 2.6-fold (0.41 log units) below the measured one; low and high end bracket the measured number.
By their numbers in this assay, from the lowest: compound 1; then compounds 3, 2 and 4 (each within the scatter of the next).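

In this assay, this saturated ring carbon gets its first direct reading: phenoxy in place of cyclopropyl gives a 6.2-fold higher number from compound 1 to compound 4 (0.79 log units; beyond the scatter). The number at this position therefore depends on the group it carries, with the 4-ethoxyphenyl group and the rest of the core held constant. No evidence at hand accounts for the step.

On these data alone, whether a hydroxyl or an amine on this carbon would give a number near that of compound 1 remains open. Also open, as far as these compounds go, is whether the step holds with methylsulfanyl as the aromatic substituent.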